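Cyano analogue in a series held at the assay limit

A few compounds are considered here, and "the series" means these few. Any claim that something is new, unique, unknown or untested is made for them only; others in the source may bear on it.

Compound 1 `O=[N+]([O-])c1ccc(CN2CCC(n3cc(CC(OCc4cc(-c5ccccc5)no4)c4ccc(Br)cc4)nn3)CC2)cc1` is the reference. In a functional assay on HCT-116 cells (Homo sapiens) for cytotoxicity, with a stated time of 48 h (a higher number here means a weaker inhibitor, a lower number a stronger inhibitor), compound 1 gives only a limit, > 25000 nM, so its standing is known solely as a limit. Compound 2 `O=[N+]([O-])c1ccc(CN2CCC(n3cc(CC(OCc4cc(-c5ccc(Br)cc5)no4)c4ccc(Br)cc4)nn3)CC2)cc1` gives the same limit, > 25000 nM. The measured step is therefore unreadable: a step that the two limits leave unreadable from compound 1 to compound 2. Compound 3 `N#Cc1ccc(-c2cc(COC(Cc3cn(C4CCN(Cc5ccc([N+](=O)[O-])cc5)CC4)nn3)c3ccc(Br)cc3)on2)cc1` differs from compound 1 by cyano in place of hydrogen on an aromatic carbon, para to a large group. Because the limit of > 25000 nM in this assay, at which 2 of the 2 values shown sit, shows both measured values at the limit, no direction can be read for this change. Compound 3 is expected to remain at the limit, estimated at 30000 nM (range 15000 nM to 100000 nM). The expected step that the limit leaves unreadable from compound 1 to compound 3 is estimated as none beyond the scatter.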

Compound 3, half-maximal inhibitory concentration: > 25000 nM
Compound 3: a limit, no number (the forecaster's own chance of this, stated with the estimate: 85%); the middle value does not contradict the limit.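

No step can be read from compound 1 or compound 2 to compound 3 in this assay: the limit of > 25000 nM in this assay, at which 3 of the 3 values shown sit.

The compounds shown leave open whether hydrogen, bromo and cyano on this aromatic carbon differ at all in cytotoxicity.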